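Nitro in Place of Methoxy on the Aryl Ring

The source may hold more compounds than are shown below. What is called first, only, known or untested is meant among the compounds shown, and "the series" means these compounds.

Compound 1 `C=C1C(=O)ON(C)C1c1ccccc1` gives 4960 nM in a functional assay on NALM-6 cells (Homo sapiens) for antiproliferative activity; on this read-out higher numbers stand for weaker inhibition and lower numbers for stronger inhibition. Compound 2 `C=C1C(=O)ON(C)C1c1ccc(C)cc1` gives 5800 nM in this assay, and compound 3 `C=C1C(=O)ON(C)C1c1ccc(OC)cc1` gives 5500 nM. Compound 3 therefore sits within the usual scatter of both other compounds: a 1.1-fold higher number from compound 1 to compound 3 (0.04 log units; within the scatter) and a 1.1-fold lower number from compound 2 to compound 3 (0.02 log units; within the scatter), just as a 1.2-fold higher number from compound 1 to compound 2 (0.07 log units; within the scatter). Compound 4 `C=C1C(=O)ON(C)C1c1ccc([N+](=O)[O-])cc1` differs from compound 3 by nitro in place of methoxy on an aromatic carbon. Among the compounds with values here, two measured steps bear on this change, since both alter the same aromatic carbon: a 1.1-fold higher number from compound 1 to compound 3 (0.04 log units; within the scatter) and a 1.1-fold lower number from compound 2 to compound 3 (0.02 log units; within the scatter), neither reaching beyond the scatter. Within the data shown here, no measured step introduces a nitro group, so compound 4 is expected to show a 1.1-fold lower number from compound 3 to compound 4 (0.02 log units; within the scatter), in neither direction beyond the scatter. Compound 4 is accordingly estimated at 5200 nM, within a range from 2600 nM to 11000 nM.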

Compound 4, half-maximal inhibitory concentration: 5200 nM
For compound 4 middle estimate and measured number coincide at the digits printed, within the range that was stated.
By their numbers in this assay, from the lowest: compounds 1, 4, 3 and 2 (each within the scatter of the next).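

Nitro on this aromatic carbon keeps the number within the scatter of all three earlier compounds (a 1.1-fold lower number from compound 3 to compound 4 (0.02 log units; within the scatter)) (a 1.1-fold lower number from compound 2 to compound 4 (0.05 log units; within the scatter)) (a 1.0-fold higher number from compound 1 to compound 4 (0.02 log units; within the scatter)). Hydrogen, methyl, methoxy and nitro at this carbon therefore read alike in this assay, which extends the flat picture to a group with more heavy atoms and hydrogen-bond acceptors than methoxy. No measurement at hand accounts for this flat reading.

Going by these compounds, whether an amine or a carboxylic acid on this carbon would reach beyond the scatter remains open. So does whether changes elsewhere on the shared core would move the number.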